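Swapping chloro for nitro: a small expected step

The source may report more compounds than this note shows. Statements on the series, on what has been measured and on what is new or still open speak of the compounds shown alone.

compound 1 `O=C(Nc1ccc(Cl)cc1Cl)c1cc(F)ccc1O` gives 880 nM
compound 2 `O=C(Nc1ccc(OC(F)(F)F)c(Cl)c1)c1ccc(C(F)(F)F)cc1O` gives 790 nM

In a functional assay on Jurkat cells (Homo sapiens) for cytotoxicity, read by luminescence and CellTiter-Glo, with a stated time of 3 days (on this read-out higher numbers stand for weaker inhibition and lower numbers for stronger inhibition), compound 1 gives 880 nM and compound 2 gives 790 nM and these two values lie within the usual scatter of each other, so neither ranks ahead. Compound 3 `O=C(Nc1ccc([N+](=O)[O-])cc1Cl)c1cc(F)ccc1O` has nitro in place of chloro on an aromatic carbon and has not been measured. For the measured compounds named here, no measured pair differs in one place only, so this expectation rests on little. The expected step is small, a 1.8-fold lower number from compound 1 to compound 3 (0.25 log units; within the scatter) by estimate, staying within the scatter and leaning toward stronger inhibition. For compound 3 the estimated value is 500 nM with an expected range from 150 nM to 1800 nM in this assay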

Compound 3, half-maximal inhibitory concentration: 530 nM
Estimate against measurement, compound 3: 1.1-fold (0.03 log units) below; the range from low to high includes it.
By their numbers in this assay, from the lowest: compounds 3, 2 and 1 (each within the scatter of the next).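

For the compounds shown here, compound 1 and compound 3 form the first pair here that differs in one place only: nitro replaces chloro on an aromatic carbon, and in this assay this gives a 1.7-fold lower number from compound 1 to compound 3 (0.22 log units; within the scatter). At this position, then, three heavy atoms with hydrogen-bond acceptors can stand in place of a single chlorine with no step beyond the scatter. No measurement shown bears on this result. Going by these compounds, it remains open how an amine or a carboxylic acid at this position would read, and whether nitro in place of chloro would give a similar step on a different core.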